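Thiourea in place of cyanoguanidine on the butyl-linked core

The compounds below may be only part of what the source reports. "The series", "measured", "known", "first", "only" and "open" are said of these compounds alone.

Compound 2 `C/N=C(/NC#N)NCCCCCn1nc(-c2ccccc2)ccc1=O` is the lower of the two measured compounds in a functional assay on the whole organism with Rattus norvegicus as the target, at a dose of 100 mg/kg (on this read-out lower numbers stand for less inhibition and higher numbers for more inhibition at the one dose given (going by the name of the read-out)), at 47.6%; compound 1 `CN(C)/C(=N/CCCCn1nc(-c2ccccc2)ccc1=O)NC#N` gives 80.7%. Compound 3 `C/N=C(\S)NCCCCn1nc(-c2ccccc2)ccc1=O` differs from compound 2 by a group of 5 heavy atoms (2 carbon, 2 nitrogen, 1 sulfur; no ring) in place of a group of 8 heavy atoms (4 carbon, 4 nitrogen; no ring), on a saturated chain carbon, four bonds along the chain from an aromatic nitrogen. Among the measured compounds shown here, the one measured step, a number 33.1 percentage points lower from compound 1 to compound 2 (beyond the scatter), changes a different part of the same group and does not bear directly on this exchange. With nothing to anchor the step, compound 3 is estimated to give 50% in this assay, within 15% to 85%, which means a step of a number 2.4 percentage points higher from compound 2 to compound 3 (within the scatter) that is expected to lie within the scatter.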

Compound 3, a percentage reported as inhibition, in the whole organism at one dose (the size of the read-out at that dose, not a potency): 87.1%
The estimate for compound 3 lay 37.1 percentage points below the measured number; measured number above the stated range.
By their numbers in this assay, from the lowest: compound 2; then compounds 1 and 3 (each within the scatter of the next).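

In this assay the thiourea group of 5 heavy atoms, in place of the group of 8 heavy atoms on the saturated chain carbon, gives a number 39.5 percentage points higher from compound 2 to compound 3 (beyond the scatter) and shows that a cyanoguanidine is not needed at this place for a high number. Measured against the other cyanoguanidine, the same kind of exchange gives a number 6.4 percentage points higher from compound 1 to compound 3 (within the scatter) and so separates neither group from the other. Nothing measured here accounts for these steps.

Going by these compounds, whether a urea or a simple amine at this chain carbon would keep the number remains open. So does how the thiourea would fare on a longer chain.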